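Thiophene for Benzofuran on Two Related Nucleoside Cores

The compounds below may be only part of what the source reports. "The series", "measured", "known", "first", "only" and "open" are said of these compounds alone.

Measured compounds:
compound 1 `Cc1ncnc2c1c(-c1cc3ccccc3o1)cn2[C@@H]1O[C@H](CO)[C@@H](O)[C@H]1O`: > 20000 nM
compound 2 `Cc1nc(N)c2c(-c3cc4ccccc4o3)cn([C@@H]3O[C@H](CO)[C@@H](O)[C@H]3O)c2n1`: > 20000 nM
compound 3 `Cc1ncnc2c1c(-c1ccsc1)cn2[C@@H]1O[C@H](CO)[C@@H](O)[C@H]1O`: 4720 nM

In a functional assay on HepG2 cells (Homo sapiens) for antiproliferative activity, read by XTT assay, with a stated time of 72 h (a higher number here means a weaker inhibitor, a lower number a stronger inhibitor), compound 1 reaches only > 20000 nM, which is a limit of the assay and not a number. Compound 3 gives 4720 nM in this assay. The two differ by one change, (thiophen-3-yl in place of 1-benzofuran-2-yl on an aromatic carbon), and the step is an at least 4.2-fold lower number from compound 1 to compound 3 (0.62 log units; beyond the scatter); this is set against (the limit of > 20000 nM in this assay, at which 2 of the 3 values shown sit), so its true size is open at the upper end.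

Compound 2 also sits at > 20000 nM, a limit of the assay. The difference between the cores of compound 1 and compound 2 is not broken down here.

Compound 4 `Cc1nc(N)c2c(-c3ccsc3)cn([C@@H]3O[C@H](CO)[C@@H](O)[C@H]3O)c2n1` has not yet been measured. It differs from compound 2 by thiophen-3-yl in place of 1-benzofuran-2-yl on an aromatic carbon, the same change as that from compound 1 to compound 3, at a place described in identical words. Compound 4 is expected to show a step of an at least 2.5-fold lower number from compound 2 to compound 4 (0.39 log units; beyond the scatter), an estimate resting on the measured at least 4.2-fold lower number from compound 1 to compound 3 (0.62 log units; beyond the scatter) and on the starting point of compound 2 being (the limit of > 20000 nM in this assay, at which 2 of the 3 values shown sit). Compound 4 is therefore estimated at 8000 nM, most likely between 2500 nM and 30000 nM, with a fair chance that only a limit is reported.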

Compound 4, half-maximal inhibitory concentration: > 20000 nM
Compound 4 was reported as a limit; the forecaster's own chance of this, stated with the estimate: 40%; middle value at least 2.5-fold (0.39 log units) from the limit.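

In this assay compound 4 gives > 20000 nM, a limit of the assay and not a number. With compound 2 also at a limit, no step between the two can be read: the limit of > 20000 nM in this assay, at which 3 of the 4 values shown sit.

The compounds shown leave open whether thiophen-3-yl in place of 1-benzofuran-2-yl changes the number at all on the core of compound 2, as it does on the core of compound 1.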